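The source may report more compounds than this note shows. Statements on the series, on what has been measured and on what is new or still open speak of the compounds shown alone.

Measured in a functional assay on A549 cells (Homo sapiens) for antiproliferative activity, read by MTT assay, with a stated time of 48 h; a lower number here means a stronger inhibitor, a higher number a weaker inhibitor:
- compound 1 `CCOc1ccc(-c2cc3c(cn2)[nH]c(=O)n3-c2cc(OC)c(OC)c(OC)c2)cc1F`: 2540 nM
- compound 2 `COc1ccc(-c2cc3c(cn2)n(C)c(=O)n3-c2cc(OC)c(OC)c(OC)c2)cc1O`: 3520 nM

Compound 2, at 3520 nM, stands within the scatter of compound 1, at 2540 nM, so the two numbers do not separate them. Compound 3 `COc1ccc(-c2cc3c(cn2)n(C2CC2)c(=O)n3-c2cc(OC)c(OC)c(OC)c2)cc1O` departs from compound 2 at one place: cyclopropyl in place of methyl on an aromatic nitrogen. Going by the values given here, no measured pair isolates this change, so any forecast is weakly grounded. In this assay no step beyond the scatter is expected, and no direction is favoured. The expected step is a 1.2-fold lower number from compound 2 to compound 3 (0.07 log units; within the scatter). The estimate for compound 3 is 3000 nM, with an expected range of 1000 nM to 9000 nM.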

Compound 3, half-maximal inhibitory concentration: > 20000 nM
Compound 3: no number, only a limit; the forecaster's own chance of this, stated with the estimate: 10%; middle value at least 6.6-fold (0.82 log units) away from the limit.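

Compound 3 gives > 20000 nM in this assay, a limit and not a number: the limit of > 20000 nM in this assay, at which 1 of the 3 values shown sits. Cyclopropyl in place of methyl on the aromatic nitrogen gives an at least 5.6-fold higher number from compound 2 to compound 3 (0.75 log units; beyond the scatter), the only single-place change in the series so far. The group on this nitrogen therefore matters to the read-out, although this rests on one pair.

Going by these compounds, whether the ring itself or the added carbons drive the step stays open. An ethyl or a longer chain on this nitrogen, or a chain ending in an amine, would help to separate the two.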